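Cytotoxicity notes on a piperidine-amide series

The source may report more compounds than this note shows. Statements on the series, on what has been measured and on what is new or still open speak of the compounds shown alone.

Compound 2 `COC(=O)C[C@H](NC(=O)OC(C)(C)C)C(=O)N(C)C1(C(=O)NCc2ccccc2)CCN(Cc2ccccc2)CC1` sits level with compound 1 `COC(=O)C[C@H](NC(=O)OC(C)(C)C)C(=O)N(Cc1ccc(F)cc1)C(C)(C)C(=O)NCc1ccccc1` on the numbers so far: in an ADME assay on MDCK cells (Canis lupus familiaris) for cytotoxicity, read by microscopy, with a stated time of 72 h (on this read-out higher numbers stand for lower toxicity in this test and lower numbers for higher toxicity in this test), compound 2 gives 20000 nM, and compound 1 gives 20000 nM, with no change between them at the digits shown. Compound 3 `COC(=O)C[C@H](NC(=O)OC(C)(C)C)C(=O)N(Cc1ccc(C)cc1)C1(C(=O)NCc2ccccc2)CCN(Cc2ccccc2)CC1` carries 4-methylphenyl in place of hydrogen on a saturated chain carbon bound to an amide-type nitrogen. For the measured compounds named here, no measured step involves this kind of change, so no step beyond the scatter is expected from compound 2 to compound 3 in this assay, and the estimated step is no change at the digits printed from compound 2 to compound 3 (within the scatter). Compound 3 is expected to give about 20000 nM in this assay, within 6000 nM to 40000 nM.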

Compound 3, minimum cytotoxic concentration: > 100000 nM
Compound 3 ended at the assay's limit; the forecaster's own chance of this, stated with the estimate: 55%; middle value at least 5.0-fold (0.69 log units) away from the limit.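

In this assay the change from methyl to 4-methylbenzyl gives an at least 5.0-fold higher number from compound 2 to compound 3 (0.69 log units; beyond the scatter) and so shows that this position, on a saturated chain carbon bound to an amide-type nitrogen, does register in this read-out. Compound 3 stands at a limit of the assay, not at a number: the limit of > 100000 nM in this assay, at which 1 of the 3 values shown sits.

Going by these compounds, how far the read-out lies beyond that limit stays open. Also open, on these data alone, is whether a plain ethyl group here, or a benzyl group carrying an amine or a carboxylic acid in place of the 4-methyl, would move the read-out the same way.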